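The source may hold more compounds than are shown below. What is called first, only, known or untested is meant among the compounds shown, and "the series" means these compounds.

Within the data shown here, in a functional assay on MDA-MB-231 cells (Homo sapiens) for inhibition, read by MTT assay, with a stated time of 48 h (a higher number here means a weaker inhibitor of growth, a lower number a stronger inhibitor of growth), compound 3 `FC(F)(F)c1ccc(NC(=S)Nc2ccc3ncnc(Nc4cccc(Br)c4)c3c2)cc1` gives 12200 nM, the lowest number so far. Compound 2 `O=S(=O)(Nc1nccs1)c1ccc(NC(=S)Nc2ccc3ncnc(Nc4cccc(Br)c4)c3c2)cc1` is reported only as a limit of the assay, > 30000 nM. Among the measured compounds shown here, the one measured step is an at least 2.4-fold lower number from compound 2 to compound 3 (0.39 log units; beyond the scatter), with trifluoromethyl in place of (1,3-thiazol-2-yl)sulfamoyl on an aromatic carbon. Compound 4 `S=C(NCc1ccc(Cl)cc1)Nc1ccc2ncnc(Nc3cccc(Br)c3)c2c1` instead carries 4-chlorobenzyl in place of 4-(trifluoromethyl)phenyl on an amide-type nitrogen. That measured step involves a different change, so it offers only loose guidance. Compound 1 `Cc1cccc(Nc2ncnc3ccc(NC(=S)NCc4ccccc4)cc23)c1C` also has a benzyl group on that nitrogen, though it differs elsewhere too, and gives 28700 nM. The expected change is small, a 1.5-fold higher number from compound 3 to compound 4 (0.17 log units; within the scatter), leaning toward a higher number. The estimated value for compound 4 is 18000 nM, with an expected range of 8000 nM to 32000 nM.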

Compound 4, concentration for 50% growth inhibition: 23000 nM
The estimate for compound 4 lay 1.3-fold (0.11 log units) below the measured number, within the range that was stated.
By their numbers in this assay, from the lowest: compounds 3, 4 and 1 (each within the scatter of the next, the first and the last beyond it). At a limit, above all of these: compound 2.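

In this assay, 4-chlorobenzyl in place of 4-(trifluoromethyl)phenyl on an amide-type nitrogen gives a 1.9-fold higher number from compound 3 to compound 4 (0.28 log units; within the scatter). Among these compounds, this is the first measured change on this nitrogen, and it shows that these two aromatic groups cannot be told apart here. Nothing measured here explains the step.

On these data alone, it remains open how much of the step comes from the benzyl link and how much from chlorine replacing trifluoromethyl. The compounds shown also leave open what a group without an aromatic ring, such as a plain alkyl chain or an amine, would do on this nitrogen.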